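A few compounds are considered here, and "the series" means these few. Any claim that something is new, unique, unknown or untested is made for them only; others in the source may bear on it.

Of the compounds shown here, two sharing a core have been measured in a physicochemical assay for solubility, in phosphate buffer, with a stated time of 24 h, at pH 7.4, tested at 100 uM; a higher number here means a more soluble compound, a lower number a less soluble compound. Compound 1 `O=C(NCc1ccc(S(=O)(=O)c2ccccc2)cc1)NCc1cccnc1` gives 10000 nM in this assay. Compound 2 `CC(C)n1cc(S(=O)(=O)c2ccc(CNC(=O)N3Cc4ccncc4C3)cc2)cn1` gives 192000 nM in this assay, the higher of the two numbers; the number for compound 1 is lower by a gap well beyond the scatter. The next compound, compound 3 `O=C(NCc1ccc(S(=O)(=O)N2CCOCC2)cc1)N1Cc2ccncc2C1`, has not yet been measured in this assay. It is built from compound 2 by one exchange: morpholin-4-yl in place of 1-isopropyl-1H-pyrazol-4-yl on a sulfonyl sulfur. Among the measured compounds shown here, no pair of measured compounds differs in only one place, so there is no measured step of this kind to lean on, and the two measured numbers alone do not say how such an exchange behaves. The expectation is therefore modest: in this assay the step of a 1.0-fold higher number from compound 2 to compound 3 (0.02 log units; within the scatter) is expected to be small, leaning toward a slightly higher number if anything, but not clearly beyond the usual scatter. Compound 3 is expected to give about 200000 nM in this assay, with a plausible range from 80000 nM to 450000 nM.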

Compound 3, solubility: 59000 nM
Beside the measured number, compound 3's estimate is 3.4-fold (0.53 log units) above it; the whole stated range lies above it.
By their numbers in this assay, from the lowest: compound 1; then compound 3; then compound 2.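

In this assay, among the compounds shown here, the exchange on the sulfonyl sulfur gives a 3.3-fold lower number from compound 2 to compound 3 (0.51 log units; beyond the scatter), the first measured step where only one place differs. It shows that this position is not silent: what sits on the sulfur can shift the number by more than repeated measurements would, even though the two groups share some counted features, with no hydrogen-bond donors and no net charge on either. Nothing measured here explains the size or direction of this step.

The exchange changes several things at once, as a five-membered aromatic ring carrying an isopropyl group leaves and a six-membered non-aromatic ring enters, so this single step cannot show which of these differences matters. A pyrazole ring without its isopropyl group, a piperidine ring or an open-chain dimethylamino group on the same sulfonyl sulfur would help separate them, and the question also remains whether the step would keep its size and direction on a different core.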